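The source may hold more compounds than are shown below. What is called first, only, known or untested is meant among the compounds shown, and "the series" means these compounds.

Compound 2, `C=C(C)[C@@H]1CC=C(Cn2cc(COc3ccc(C4NC(=O)NC5=C4C(=O)CC(C)(C)C5)cc3)nn2)CC1`, is tested in a functional assay on OVCAR-3 cells (Homo sapiens) for inhibition, read by sulforhodamine B assay, with a stated time of 48 h (on this read-out higher numbers stand for weaker inhibition of growth and lower numbers for stronger inhibition of growth), where compound 2 gives 29300 nM. Compound 1, `C=C(C)[C@@H]1CC=C(Cn2cc(COc3cccc(C4NC(=O)NC(C)=C4C(=O)OCC)c3)nn2)CC1`, sits close by in this assay with 18500 nM, a gap that falls within the usual scatter, so the two cannot be ranked. Compound 3, `C=C(C)[C@@H]1CC=C(Cn2cc(COc3cccc(C4NC(=O)NC5=C4C(=O)CC(C)(C)C5)c3)nn2)CC1`, reaches only the limit of this assay, reported as > 100000 nM, which is a boundary rather than a number. Compound 4, `C=C(C)[C@@H]1CC=C(Cn2cc(COc3ccc(C4NC(=O)NC5=C4C(=O)CC(C)(C)C5)cc3OC)nn2)CC1`, differs from compound 2 by one change: methoxy in place of hydrogen on an aromatic carbon. Within the data shown here, no pair of measured compounds shows this change, so the expected step from compound 2 to compound 4 in this assay is set at a 1.2-fold lower number from compound 2 to compound 4 (0.07 log units; within the scatter), which is no larger than the scatter. Compound 4 is therefore estimated at 25000 nM, within a range from 8000 nM to 80000 nM.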

Compound 4, concentration for total growth inhibition: 95000 nM
For compound 4 the middle estimate is 3.8-fold (0.58 log units) below the measured one, and the stated range ends below it.
By their numbers in this assay, from the lowest: compounds 1 and 2 (each within the scatter of the next); then compound 4. At a limit, above all of these: compound 3.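

In this assay, placing methoxy on this aromatic carbon, ortho to a large group and meta to a large group, weakens growth inhibition, with a 3.2-fold higher number from compound 2 to compound 4 (0.51 log units; beyond the scatter). This place on the ring is therefore not indifferent to change: a group of only 2 heavy atoms moves the number beyond the scatter. The result now lies not far from the end of what this read-out reports: the limit of > 100000 nM in this assay, at which 1 of the 4 values shown sits.

Whether any group here raises the number, or only methoxy does, stays open: a hydroxyl, a fluorine or an amine at this place is not among the compounds shown. From the compounds shown here alone, what causes the step also stays open.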